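Swapping fluorophenyl for benzyl on a weakly active triazole

The compounds below may be only part of what the source reports. "The series", "measured", "known", "first", "only" and "open" are said of these compounds alone.

Among the measured compounds shown here, in a functional assay on HeLa cells (Homo sapiens) for antiproliferative activity, read by MTT assay, with a stated time of 72 h (on this read-out higher numbers stand for weaker inhibition and lower numbers for stronger inhibition), compound 2 `O=c1nc2oc(CCCCl)cc2cn1Cc1cn(-c2ccccc2F)nn1` gives 66500 nM, the only full number in this small set. For compound 1 `CCCCCCc1cc2cn(Cc3cn(-c4ccccc4F)nn3)c(=O)nc2o1` this assay reports only a limit, > 100000 nM. For compound 3 `CCCCCCC#Cc1c(CCCCCC)oc2nc(=O)n(Cc3cn(-c4ccc(Cl)cc4)nn3)cc12` the result is likewise a limit, > 100000 nM. Two of the three values therefore sit at the limit of > 100000 nM in this assay, at which 2 of the 3 values shown sit. For the measured compounds named here, the one measured step, an at least 1.5-fold lower number from compound 1 to compound 2 (0.17 log units; that floor lies within the scatter), concerns the side chain, not the ring that changes here. Compound 4 `O=c1nc2oc(CCCCl)cc2cn1Cc1cn(Cc2ccccc2)nn1` differs from compound 2 by benzyl in place of 2-fluorophenyl on an aromatic nitrogen. Going by the values given here, no measured step bears on a change at this ring nitrogen, so no shift beyond the scatter in this assay is expected. Compound 4 is estimated at 66500 nM, within 25000 nM to 200000 nM, an expected step of no change at the digits printed from compound 2 to compound 4 (within the scatter).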

Compound 4, half-maximal inhibitory concentration: 9580 nM
Beside the measured number, compound 4's estimate is 6.9-fold (0.84 log units) above it, and the stated range ends above it.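

Benzyl in place of 2-fluorophenyl on this aromatic nitrogen gives a 6.9-fold lower number from compound 2 to compound 4 (0.84 log units; beyond the scatter) in this assay and is the first measured sign that the group held here affects this read-out. The two groups have the same number of heavy atoms and each holds one six-membered aromatic ring of carbon only, yet the values still differ. No measurement shown accounts for this step.

The compounds shown leave open whether the lower number goes with losing the fluorine or with the added carbon of benzyl. A plain phenyl group on this nitrogen would help separate the two.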